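A few compounds are considered here, and "the series" means these few. Any claim that something is new, unique, unknown or untested is made for them only; others in the source may bear on it.

Measured in a functional assay on THP-1 cells (Homo sapiens) for inhibition, read by ELISA, with stated times of 1 h and 18 h; on this read-out lower numbers stand for stronger inhibition and higher numbers for weaker inhibition:
- Compound 1 `NC(=O)[C@@H]1[C@H](Nc2nc(Nc3ccc(C(=O)N4CCCC4)cc3)ncc2-c2cccnc2)[C@H]2C=C[C@@H]1C2`: 230 nM
- Compound 2 `Cc1cnc(Nc2cccc(C(=O)N3CCCC3)c2)nc1N[C@H]1[C@@H](C(N)=O)[C@@H]2C=C[C@H]1C2`: 100 nM
- Compound 3 `NC(=O)[C@@H]1[C@H](Nc2nc(Nc3cccc(C(=O)N4CCCC4)c3)ncc2C2CC2)[C@H]2C=C[C@@H]1C2`: 90 nM

Compound 3 and compound 2 stand level within the usual scatter of repeated measurements. The number for compound 1, 230 nM, lies higher than that of compound 3, and this gap is beyond the scatter.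

The next compound to be tested is compound 4 `NC(=O)[C@@H]1[C@H](Nc2nc(Nc3cccc(C(=O)N4CCCC4)c3)ncc2-c2ccccc2)[C@H]2C=C[C@@H]1C2`. It has phenyl in place of cyclopropyl on an aromatic carbon of a six-membered aromatic ring with 2 nitrogen: phenyl in place of cyclopropyl on an aromatic carbon.

For the measured compounds named here, only one measured step changes this carbon alone. That step, a 1.1-fold lower number from compound 2 to compound 3 (0.05 log units; within the scatter), puts cyclopropyl in place of methyl and stays within the scatter. It gives no sign that this carbon responds strongly to a change of group, although it never tests an aromatic ring there. Compound 1 does carry an aromatic ring on this carbon and gives 230 nM, but it also differs elsewhere, so it is only a loose warning of a rise.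

In this assay, the expected change is small and slightly upward, with no step beyond the scatter: a 1.4-fold higher number from compound 3 to compound 4 (0.16 log units; within the scatter). The estimate for compound 4 is 130 nM, with an expected range from 45 nM to 380 nM.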

Compound 4, half-maximal inhibitory concentration: 220 nM
Estimate against measurement, compound 4: 1.7-fold (0.23 log units) below; measured number inside the range.
By their numbers in this assay, from the lowest: compounds 3 and 2 (each within the scatter of the next); then compounds 4 and 1 (each within the scatter of the next).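

In this assay, this aromatic carbon proves sensitive to the group it carries: phenyl in place of cyclopropyl gives a 2.4-fold higher number from compound 3 to compound 4 (0.39 log units; beyond the scatter), and phenyl in place of methyl gives a 2.2-fold higher number from compound 2 to compound 4 (0.34 log units; beyond the scatter). The earlier swap of methyl for cyclopropyl, a 1.1-fold lower number from compound 2 to compound 3 (0.05 log units; within the scatter), stayed within the scatter, so among these three compounds, which differ only at this carbon, phenyl alone produces a step beyond it, though both of its steps are modest. Nothing available here explains why phenyl behaves differently from the two smaller groups.

For the compounds shown here, with only three groups compared on this carbon, it remains open whether the higher number goes with the aromatic ring or simply with a larger group, a question that cyclohexyl, a six-membered ring that is not aromatic, could help to separate. Also open, from the compounds shown here alone, is how a phenyl ring carrying an amine or a carboxylic acid would read on the rest of compound 4, and compound 1 cannot settle what a nitrogen-containing ring does here, since it also differs elsewhere.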